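A few compounds are considered here, and "the series" means these few. Any claim that something is new, unique, unknown or untested is made for them only; others in the source may bear on it.

Compound 3 `CCCc1ncc2cnnc(S)n12` has been tested in a functional assay for inhibition, with Homo sapiens as the target (on this read-out lower numbers stand for stronger inhibition and higher numbers for weaker inhibition), where compound 3 gives > 48000 nM, which is a limit of the assay and not a number. Compound 1 `Sc1nncc2cncn12` likewise gives > 48000 nM, again a limit rather than a number. Compound 2 `Cc1ncc2cnnc(O)n12` gives > 48000 nM, also a limit. Among the compounds with values here, the only step between measured compounds that differ in a single place is a step that the two limits leave unreadable from compound 1 to compound 3, and its size cannot be read because all three values sit at the limit of > 48000 nM in this assay, at which 3 of the 3 values shown sit. Compound 4 `Cc1ncc2cnnc(S)n12` is not yet measured; it differs from compound 3 by hydrogen in place of ethyl on a saturated chain carbon bound to an aromatic carbon. Within the data shown here, no measured step bears readably on this change, so no step beyond the scatter is expected, and the expected step is a step that the limit leaves unreadable from compound 3 to compound 4. Compound 4 is therefore estimated at 100000 nM, with a range from 30000 nM to 500000 nM, most likely reported again only as a limit.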

Compound 4, half-maximal inhibitory concentration: > 48000 nM
Compound 4 ended at the assay's limit; the forecaster's own chance of this, stated with the estimate: 85%; the middle value lies beyond the limit too.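

No step from compound 1, compound 2 or compound 3 to compound 4 can be read, because each value is a limit and not a number: the limit of > 48000 nM in this assay, at which 4 of the 4 values shown sit.

The compounds shown leave open what structure would give a readable value in this assay.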